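The source may report more compounds than this note shows. Statements on the series, on what has been measured and on what is new or still open speak of the compounds shown alone.

Measured so far in an ADME assay on liver for metabolic stability, with Liver microsome (Homo sapiens) as the target, read by LC-MS, using microsomes, with a stated time of 5 h; a lower number here means slower removal, a higher number faster removal of the compound:
- compound 1 `C[C@]1(c2ccc(OC(F)(F)F)cc2)C[C@@](O)(c2ccccn2)CO1`: 117 mL/min/kg
- compound 2 `O[C@@]1(c2ccccn2)CC[C@H](c2ccc(C(F)(F)F)cc2)C1`: 400 mL/min/kg

Of these two compounds, compound 1 has the lower number, at 117 mL/min/kg. Compound 2 stands higher at 400 mL/min/kg, and the gap between them lies beyond the scatter of repeated measurements. Compound 1 is therefore the slower-cleared of the pair in this assay.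

The next compound to be tested is compound 3 `C[C@]1(c2ccc(OC(F)(F)F)cc2)C[C@](O)(c2ccccn2)CO1`, which is closely related to compound 1. The change is the two compounds have the same atoms and bonds and differ only in configuration as drawn: 1 of 2 stereo elements differ; a stereocentre at a saturated ring carbon is drawn R in compound 1 and S in compound 3: the two compounds have the same atoms and bonds, and a stereocentre at a saturated ring carbon is drawn R in compound 1 and S in compound 3.

Going by the values given here, no measured pair here shows what such a change in configuration does to the number, so there is no firm basis for a direction. The expectation is a step no larger than the scatter, though a larger one cannot be excluded.

The estimated change is a 1.1-fold higher number from compound 1 to compound 3 (0.05 log units; within the scatter).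

For compound 3 the expected value is 130 mL/min/kg, with an estimated range of 60 mL/min/kg to 300 mL/min/kg.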

Compound 3, clearance: 117 mL/min/kg
For compound 3 the middle estimate is 1.1-fold (0.05 log units) above the measured one, within the range that was stated.
By their numbers in this assay, from the lowest: compounds 1 and 3 (each within the scatter of the next); then compound 2.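

In this assay, moving this stereocentre at a saturated ring carbon from R to S gives no change at the digits printed from compound 1 to compound 3 (within the scatter). Going by these compounds alone, this is the first pair to isolate configuration, and it gives no sign that the number depends on how this centre is drawn, at least with the rest of the core of compound 1 held fixed. The reading applies to this one centre and rests on a single pair, in which the only structural difference is the one at this position: the fact that compounds 1 and 3 differ only in the configuration as drawn.

The compounds shown leave open whether the other stereo element would behave in the same way, since it stays as drawn in this pair, and whether the same indifference to configuration would hold on a different core. They also leave open how the number would respond if an amine or a carboxylic acid were carried on the shared core, a change that would test this position and the rest of the scaffold in a way that a change of configuration alone cannot.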